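Aryl substituent exchanges on the shared core: working notes

A few compounds are considered here, and "the series" means these few. Any claim that something is new, unique, unknown or untested is made for them only; others in the source may bear on it.

compound 1, `CN1CCN(CCCOc2cccc3nc(Nc4ccc(Cl)c(C(F)(F)F)c4)ccc23)CC1`, in a functional assay on HCT-15 cells (Homo sapiens) for inhibition, read by sulforhodamine B assay, with a stated time of 48 h; a lower number here means a stronger inhibitor of growth, a higher number a weaker inhibitor of growth: 1220 nM
compound 2, `CN1CCN(CCCOc2cccc3nc(Nc4ccc(Cl)c(F)c4)ccc23)CC1`: 1400 nM
compound 3, `CN1CCN(CCCOc2cccc3nc(Nc4cc(Cl)cc(Cl)c4)ccc23)CC1`: 1420 nM

Compound 3 stands at the highest number of the three, yet a 1.0-fold higher number from compound 2 to compound 3 (0.01 log units; within the scatter) and a 1.2-fold higher number from compound 1 to compound 3 (0.07 log units; within the scatter) both lie within the scatter, as does a 1.1-fold higher number from compound 1 to compound 2 (0.06 log units; within the scatter). The three aryl patterns so far are indistinguishable on these numbers.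

Compound 4, `CN1CCN(CCCOc2cccc3nc(Nc4cccc(Cl)c4)ccc23)CC1`, has not yet been measured. It differs from compound 3 by hydrogen in place of chloro on an aromatic carbon. Among the measured compounds shown here, no measured step removes a chloro group outright; the nearest comparisons are the aryl exchanges above, all within the scatter. A step in this assay of no more than the scatter is therefore expected, in no firm direction. For compound 4 the estimate is 1600 nM, within 700 nM to 3600 nM. That estimate means an expected 1.1-fold higher number from compound 3 to compound 4 (0.05 log units; within the scatter).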

Compound 4, concentration for 50% growth inhibition: 1580 nM
Estimate against measurement, compound 4: 1.0-fold (0.01 log units) above, within the range that was stated.
By their numbers in this assay, from the lowest: compounds 1, 2, 3 and 4 (each within the scatter of the next).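

Removing a chloro from the 3,5-dichlorophenyl group gives a 1.1-fold higher number from compound 3 to compound 4 (0.05 log units; within the scatter) in this assay, so the first outright loss of a substituent at this position leaves the number within the scatter. The exchanges for 3-chlorophenyl give a 1.1-fold higher number from compound 2 to compound 4 (0.05 log units; within the scatter) and a 1.3-fold higher number from compound 1 to compound 4 (0.11 log units; within the scatter), so a single chloro matches the two-substituent patterns on these numbers. Nothing available explains this flat response.

Whether the remaining chloro matters stays open, since every aryl group shown carries at least one chloro. An unsubstituted phenyl, or an amine or a carboxylic acid on this ring, would test the limits of this tolerance.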